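A few compounds are considered here, and "the series" means these few. Any claim that something is new, unique, unknown or untested is made for them only; others in the source may bear on it.

Compound 1 `CCCCC[Se]c1nc(NCc2ccccc2)c2ccccc2n1` is a measured compound; in an ADME assay on BEAS-2B cells (Homo sapiens) for cytotoxicity, read by MTT assay, with a stated time of 72 h (on this read-out higher numbers stand for weaker inhibition of growth and lower numbers for stronger inhibition of growth), compound 1 gives only a limit, > 100000 nM. Compound 2 `CSc1nc(NCc2ccc([Se]C)cc2)c2ccccc2n1` is the second; in this assay compound 2 gives only a limit, > 100000 nM. Compound 3 `[SeH]c1nc(NCc2ccccc2)c2ccccc2n1` is the third; in this assay compound 3 gives only a limit, > 100000 nM.

Compound 3 therefore stands at the limit of this assay, as do all three shown values (the limit of > 100000 nM in this assay, at which 3 of the 3 values shown sit). Going by the values given here, the one step computed among the measured compounds, a step that the two limits leave unreadable from compound 1 to compound 3, is unreadable, with hydrogen in place of pentyl on a selenium, so it gives no size. Compound 4 `CSc1nc(NCc2ccccc2)c2ccccc2n1` differs from compound 3 by a group of 2 heavy atoms (1 carbon, 1 sulfur; no ring) in place of one selenium atom, on an aromatic carbon. Among the compounds with values here, no measured step speaks directly to this change; compound 2 carries a methylsulfanyl on the shared core and also sits at the limit. With every shown value at the limit, no step beyond the scatter is expected in this assay, and compound 4 is expected to remain at the limit as well, meaning an expected step of a number no higher from compound 3 to compound 4 (the limit leaves the size open). Compound 4 is estimated at 100000 nM, in the range 40000 nM to 100000 nM.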

Compound 4, concentration for total growth inhibition: 88200 nM
Compound 4: middle estimate off by 1.1-fold (0.05 log units), on the high side; the range from low to high includes it.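

Compound 4 is the only compound shown that gives a number rather than a limit in this assay, and the other three values sit at that limit: the limit of > 100000 nM in this assay, at which 3 of the 4 values shown sit. With methylsulfanyl in place of the selenium on this aromatic carbon between two ring nitrogen atoms, the result is an at least 1.1-fold lower number from compound 3 to compound 4 (0.05 log units; that floor lies within the scatter). The other two comparisons read the same way, with an at least 1.1-fold lower number from compound 2 to compound 4 (0.05 log units; that floor lies within the scatter) and an at least 1.1-fold lower number from compound 1 to compound 4 (0.05 log units; that floor lies within the scatter), so all three are floors and none shows a change beyond the scatter.

From the compounds shown here alone, the true size of each step stays open, as three of the four compounds give only a limit. The compounds shown also leave open whether an amine or a carboxylic acid on this carbon would bring a step beyond the scatter.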